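From Nitro to Carboxy on the Aromatic Ring

The compounds below may be only part of what the source reports. "The series", "measured", "known", "first", "only" and "open" are said of these compounds alone.

Of the compounds shown here, two sharing one core have been measured in a functional assay (mast cells) for inhibition, with Rattus norvegicus as the target; a higher number here means that more compound is needed for the effect, a lower number that less compound is needed. Compound 1 `CC1CC/C(=N\Nc2ccc(O)cc2)c2ncc(C(=O)O)c(=O)n21` gives 1300 nM, and compound 2 `CC1CC/C(=N\Nc2ccc([N+](=O)[O-])cc2)c2ncc(C(=O)O)c(=O)n21` gives 8900 nM, the higher of the two numbers. Next comes compound 3 `CC1CC/C(=N\Nc2ccc(C(=O)O)cc2)c2ncc(C(=O)O)c(=O)n21`, with carboxy in place of nitro on an aromatic carbon, para to a large group: carboxy in place of nitro on an aromatic carbon. Among the compounds with values here, only one measured step bears on this change, the swap of hydroxy for nitro at the same place, and it was modest but beyond the scatter: a 6.8-fold higher number from compound 1 to compound 2 (0.84 log units; beyond the scatter). That step shows that a swap here can move the number, yet it says nothing directly about carboxy. Compound 2 stands at 8900 nM, the top of this small range, so a modest fall is expected rather than a further rise. The expected change is a 2.5-fold lower number from compound 2 to compound 3 (0.41 log units; beyond the scatter). For compound 3 the estimate is 3500 nM, with an expected range of 900 nM to 14000 nM.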

Compound 3, half-maximal effective concentration: 1000000 nM
Estimate against measurement, compound 3: 290-fold (2.46 log units) below, and the stated range ends below it.
By their numbers in this assay, from the lowest: compound 1; then compound 2; then compound 3.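

This aromatic carbon can matter far more than the earlier pair suggested: carboxy in place of nitro gives a 110-fold higher number from compound 2 to compound 3 (2.05 log units; beyond the scatter), and carboxy in place of hydroxy gives a 770-fold higher number from compound 1 to compound 3 (2.89 log units; beyond the scatter), both much larger than a 6.8-fold higher number from compound 1 to compound 2 (0.84 log units; beyond the scatter). Nitro and carboxy have the same number of heavy atoms, so in this assay a matched heavy-atom count does not keep the number in place. Nothing measured here gives a reason for this large rise.

Going by these compounds, what remains open is whether the rise belongs to carboxy specifically or extends to other groups at this aromatic carbon. A methyl ester or an amine at the same place would help show how narrowly the large step is tied to carboxy.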